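Three aminoimidazopyridines at the solubility limit, and a carboxylic acid

A few compounds are considered here, and "the series" means these few. Any claim that something is new, unique, unknown or untested is made for them only; others in the source may bear on it.

Compound 1 `FC(F)(F)c1cccc(-c2nc3cnc(Nc4ccccn4)cc3[nH]2)c1`: < 5000 nM
Compound 2 `FC(F)(F)c1cccc(-c2nc3cnc(Nc4ncccn4)cc3[nH]2)c1`: < 5000 nM
Compound 3 `Fc1cnc(Nc2cc3[nH]c(-c4cccc(C(F)(F)F)c4)nc3cn2)c(F)c1`: < 5000 nM

In a physicochemical assay for solubility, using the shake flask method, in phosphate buffer, measured as kinetic solubility, with a stated time of 20 h, at pH 6.5 (on this read-out higher numbers stand for higher solubility and lower numbers for lower solubility), compound 1 gives only a limit, < 5000 nM. In this assay compound 2 likewise gives only a limit, < 5000 nM. Compound 3 also gives only a limit, < 5000 nM. All three values therefore sit at the same limit (the limit of < 5000 nM in this assay, at which 3 of the 3 values shown sit), so compound 3 stands nowhere that can be told apart from its two neighbours. The steps between the measured compounds carry no readable size: a step that the two limits leave unreadable from compound 1 to compound 2, a step that the two limits leave unreadable from compound 1 to compound 3 and a step that the two limits leave unreadable from compound 2 to compound 3.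

Compound 4 `O=C(O)c1ccc(Nc2cc3[nH]c(-c4cccc(C(F)(F)F)c4)nc3cn2)nc1` differs from compound 3 in one place: 5-carboxypyridin-2-yl in place of 3,5-difluoropyridin-2-yl on a nitrogen on an aromatic ring. Within the data shown here, no measured step bears on this change, since every step among compounds 1, 2 and 3 was left unreadable by the limits, and none of them exchanged a fluorinated ring for a carboxylic acid. The direction and size of the step in this assay can therefore not be read from the data. Compound 4 is expected to give a value near 8000 nM, within a wide range from 2000 nM to 60000 nM, which would mean an estimated step of an at least 1.6-fold higher number from compound 3 to compound 4 (0.20 log units; that floor lies within the scatter), with a real chance that this assay again reports only a limit.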

Compound 4, solubility: 6000 nM
Beside the measured number, compound 4's estimate is 1.3-fold (0.12 log units) above it, and the stated range covers the measured number.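

In this assay, swapping the ring on a nitrogen on an aromatic ring now gives a step with a readable floor, where every earlier exchange at this place was left unreadable by the limits: 5-carboxypyridin-2-yl in place of 3,5-difluoropyridin-2-yl gives an at least 1.2-fold higher number from compound 3 to compound 4 (0.07 log units; that floor lies within the scatter). The same kind of floor appears against the other two neighbours, with an at least 1.2-fold higher number from compound 2 to compound 4 (0.07 log units; that floor lies within the scatter) for 5-carboxypyridin-2-yl in place of pyrimidin-2-yl, and an at least 1.2-fold higher number from compound 1 to compound 4 (0.07 log units; that floor lies within the scatter) for carboxy in place of hydrogen on an aromatic carbon. Compound 4 is thus the only one of the four to carry a number rather than a limit, and the rest of the series stays where it was: the limit of < 5000 nM in this assay, at which 3 of the 4 values shown sit.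

On these data alone, compounds 1, 2 and 3 carry no number, so the true size of these three steps stays open, and each floor alone does not clear the scatter. Also open, as far as these compounds go, is whether an amine, a primary amide or a methyl ester in place of the carboxy group, or a carboxylic acid on a longer chain, would likewise give a number in this assay.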